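Swapping acetyl for dimethylamino on a pyrazole-linked phenyl

The source may hold more compounds than are shown below. What is called first, only, known or untested is meant among the compounds shown, and "the series" means these compounds.

Compound 1 `COc1cc(C)cc(-c2c(-c3ccnc(-c4ccc(C(C)=O)cc4)c3)cnn2CC#N)c1` was tested in a functional assay on LOX IMVI cells (Homo sapiens) for inhibition, read by sulforhodamine B assay, with a stated time of 48 h (on this read-out lower numbers stand for stronger inhibition of growth and higher numbers for weaker inhibition of growth), and gave 3390 nM; this is the lowest of the two numbers recorded, though its neighbour lies within the scatter. That neighbour, compound 2 `Cc1cc(O)cc(-c2nn(CC#N)cc2-c2ccnc(-c3ccc(N(C)C)cc3)c2)c1`, carries a dimethylamino group on the outer phenyl ring as well as a hydroxy group in place of the methoxy group of compound 1, and in this assay compound 2 gives 5130 nM. The unmeasured compound 3 `COc1cc(C)cc(-c2c(-c3ccnc(-c4ccc(N(C)C)cc4)c3)cnn2CC#N)c1` differs from compound 1 in one place only: dimethylamino in place of acetyl on an aromatic carbon. Among the measured compounds shown here, no single-change step between measured compounds is available, so the size of the change cannot be read from a recorded pair. Since compound 1 sits within the scatter of compound 2, which also carries the dimethylamino group and gives 5130 nM, the step from compound 1 to compound 3 is expected to be small, a 1.2-fold higher number from compound 1 to compound 3 (0.07 log units; within the scatter), in no clear direction beyond the scatter. Compound 3 is therefore estimated at 4000 nM, within 1500 nM to 11000 nM.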

Compound 3, concentration for 50% growth inhibition: 66.8 nM
Beside the measured number, compound 3's estimate is 60-fold (1.78 log units) above it; measured number outside the range, below it.
By their numbers in this assay, from the lowest: compound 3; then compounds 1 and 2 (each within the scatter of the next).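

In this assay the change from 4-acetylphenyl to 4-(dimethylamino)phenyl gives a 51-fold lower number from compound 1 to compound 3 (1.71 log units; beyond the scatter) and so shows that this place on the ring is far from indifferent to what it carries, which compounds 1 and 2 could not show, since they differ in more than one place. By the counts, both groups have three heavy atoms, one hydrogen-bond acceptor and no net charge, so a large step arises with those counts unchanged. Nothing measured here accounts for the size of this step.

As far as these compounds go, whether the step follows from gaining the amine nitrogen or from losing the carbonyl stays open, and a primary amine, methylamino or morpholine at this place would bear on that. Also open, from the compounds shown here alone, is whether the same step would hold with a hydroxy group in place of the methoxy group of compound 3.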